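Aryl ketone variation: dimethoxy versus dihalogen

A few compounds are considered here, and "the series" means these few. Any claim that something is new, unique, unknown or untested is made for them only; others in the source may bear on it.

Compound 1 `COc1cc(-c2cc(/C=C/C(=O)c3ccc(Cl)c(Cl)c3)[nH]n2)cc(OC)c1OC` gives 9560 nM in a functional assay on HCC 2998 cells (Homo sapiens) for inhibition, read by sulforhodamine B assay, with a stated time of 48 h; a lower number here means a stronger inhibitor of growth, a higher number a weaker inhibitor of growth. Within the data shown here, compound 2 `COc1ccc(C(=O)/C=C/c2cc(-c3cc(OC)c(OC)c(OC)c3)n[nH]2)cc1OC` gives 2130 nM in this assay, the lower of the two values measured so far. Among the measured compounds shown here, the one measured step, a 4.5-fold lower number from compound 1 to compound 2 (0.65 log units; beyond the scatter), is the only guide in this set, and it shows a dimethoxyphenyl on the carbonyl carbon giving a lower number than a dichlorophenyl. Compound 3 `COc1cc(-c2cc(/C=C/C(=O)c3ccc(F)c(F)c3)[nH]n2)cc(OC)c1OC` has not yet been measured. It differs from compound 2 in one place: 3,4-difluorophenyl in place of 3,4-dimethoxyphenyl on a carbonyl carbon. This change runs in the opposite sense to the measured step, from a dimethoxyphenyl back to a dihalogenated phenyl, so a higher number than compound 2 is expected in this assay, of a size comparable to that step, though fluorine is not chlorine and the set gives no direct reading for it. Compound 3 is therefore estimated at about 6500 nM, within 2500 nM to 20000 nM, an expected step of a 3.1-fold higher number from compound 2 to compound 3 (0.48 log units; beyond the scatter).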

Compound 3, concentration for 50% growth inhibition: 3690 nM
The estimate for compound 3 lay 1.8-fold (0.25 log units) above the measured number, within the range that was stated.
By their numbers in this assay, from the lowest: compounds 2 and 3 (each within the scatter of the next); then compound 1.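

In this assay, replacing 3,4-dimethoxyphenyl with 3,4-difluorophenyl on the carbonyl carbon gives a 1.7-fold higher number from compound 2 to compound 3 (0.24 log units; within the scatter) and so leaves these two groups unseparated. Compound 3 therefore goes against any reading of the earlier step as dimethoxy over dihalogen in general. The two halogens also part here, with a 2.6-fold lower number from compound 1 to compound 3 (0.41 log units; beyond the scatter) showing that 3,4-dichlorophenyl stands apart from 3,4-difluorophenyl at this place, so the earlier gap belongs to the dichloro compound rather than to dihalogen substitution as such. Nothing measured here accounts for this difference between the two halogenated groups.

Still open, from the compounds shown here alone, is whether a group of a different kind on the carbonyl carbon, such as an aminophenyl, a carboxylic acid-bearing phenyl or an unsubstituted phenyl, would separate from compound 2. The reading also rests on a single cell line.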